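Chloro in place of trifluoromethyl: compound 3 to compound 4

The source may hold more compounds than are shown below. What is called first, only, known or untested is meant among the compounds shown, and "the series" means these compounds.

Measured so far in an ADME assay on PBMC cells (Homo sapiens) for cytotoxicity; a lower number here means that less compound is tolerated, a higher number that more compound is tolerated:
- compound 1 `Cc1ccnc(OC(c2ccc(C(F)(F)F)cc2)C2CCN(C(C)CCNC(=O)c3c(Cl)cncc3Cl)CC2)c1`: 33600 nM
- compound 2 `CC(CCNC(=O)c1c(Cl)cncc1Cl)N1CCC(C(Oc2cccc(Cl)n2)c2ccc(C(F)(F)F)cc2)CC1`: > 32500 nM (a limit, not a number)
- compound 3 `CC(CCNC(=O)c1c(Cl)cncc1Cl)N1CCC(C(Oc2ccccc2C(F)(F)F)c2ccc(C(F)(F)F)cc2)CC1`: 12500 nM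

Compound 3 holds the lower of the two actual numbers in this assay, and compound 1 holds the other. The reading for compound 2 is a limit of the assay and gives only a bound.

Compound 4 `CC(CCNC(=O)c1c(Cl)cncc1Cl)N1CCC(C(Oc2ccccc2Cl)c2ccc(C(F)(F)F)cc2)CC1` keeps the core of compound 3 and carries one change: chloro in place of trifluoromethyl on an aromatic carbon, ortho to a large group (chloro in place of trifluoromethyl on an aromatic carbon).

For the measured compounds named here, no measured step makes this swap alone. The nearest evidence comes from replacing the whole group on the oxygen, which gives a 2.7-fold lower number from compound 1 to compound 3 (0.43 log units; beyond the scatter) and an at least 2.6-fold lower number from compound 2 to compound 3 (0.41 log units; beyond the scatter). The step that the limit leaves unreadable from compound 1 to compound 2 adds nothing on size. Both readable steps are modest or bounded, and the swap here touches a single substituent, so a smaller move than a 2.7-fold lower number from compound 1 to compound 3 (0.43 log units; beyond the scatter) is expected, drifting slightly upward if at all.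

The expected step is a 1.3-fold higher number from compound 3 to compound 4 (0.11 log units; within the scatter). Compound 4 is estimated at 16000 nM, with an expected range of 7000 nM to 32000 nM.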

Compound 4, half-maximal cytotoxic concentration: 4400 nM
Compound 4: middle estimate off by 3.6-fold (0.56 log units), on the high side; the whole stated range lies above it.
By their numbers in this assay, from the lowest: compound 4; then compound 3; then compound 1.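

In this assay, the swap of a single substituent on an aromatic carbon, ortho to a large group, is a readable move: chloro in place of trifluoromethyl gives a 2.8-fold lower number from compound 3 to compound 4 (0.45 log units; beyond the scatter), a step of the same order as replacing the whole group on the oxygen in a 2.7-fold lower number from compound 1 to compound 3 (0.43 log units; beyond the scatter). With 2-chlorophenyl on the oxygen the distance to the pyridine-bearing compounds widens, with a 7.6-fold lower number from compound 1 to compound 4 (0.88 log units; beyond the scatter) and an at least 7.3-fold lower number from compound 2 to compound 4 (0.86 log units; beyond the scatter), so the two compounds with a ring of carbon only, compound 3 and compound 4, hold the lowest numbers of the four and none of the compounds shown goes against this. The second of those steps is only a bound, since compound 2 is recorded as a limit: the limit of > 32500 nM in this assay, at which 1 of the 4 values shown sits.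

The compounds shown do not separate the effect of the substituent from that of the ring carrying it, and an unsubstituted phenyl, a 2-fluorophenyl or a 2-methoxyphenyl on the same oxygen would bear on that. On these data alone, whether chloro in place of trifluoromethyl gives a step of this size on a pyridine ring also remains open.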